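This account rests on a few compounds, and the source may have more. Where it says the series, first, only, none or still open, it means among the compounds named here.

Three amides built on one shared core have been measured in an assay on NIH3T3 cells with Urotensin-2 receptor (Homo sapiens) as the target; on this read-out lower numbers stand for an effect already at smaller amounts and higher numbers for an effect only at larger amounts of compound. Compound 1 `Cc1cccc(C(=O)NC(CCN(C)C)c2ccc(Cl)cc2)c1C` gives 3630 nM, and compound 2 `Cc1ccc(C)c(C(=O)NC(CCN(C)C)c2ccc(Cl)cc2)c1` gives 2880 nM; the step of a 1.3-fold lower number from compound 1 to compound 2 (0.10 log units; within the scatter) lies within the scatter. Compound 3 `CN(C)CCC(NC(=O)c1ccc(N(C)C)cc1)c1ccc(Cl)cc1` gives 1350 nM, the lowest of the three numbers, beyond the scatter from both compound 2 and compound 1. Compound 4 `CN(C)CCC(NC(=O)c1ccccc1)c1ccc(Cl)cc1` differs from compound 3 by hydrogen in place of dimethylamino on an aromatic carbon. Going by the values given here, no measured step bears directly on this change: the only recorded step concerns the dimethyl pattern on the aromatic ring and is itself within the scatter, so it says nothing about removing the substituent altogether. Compound 4 is therefore expected to show a step of a 2.6-fold higher number from compound 3 to compound 4 (0.41 log units; beyond the scatter), towards a higher number. The estimate for compound 4 is 3500 nM, with a range from 1200 nM to 10000 nM.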

Compound 4, half-maximal effective concentration: 1410 nM
Compound 4: the middle estimate sits 2.5-fold (0.39 log units) above what was measured; the range from low to high includes it.
By their numbers in this assay, from the lowest: compounds 3 and 4 (each within the scatter of the next); then compounds 2 and 1 (each within the scatter of the next).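

In this assay, hydrogen in place of dimethylamino on the aromatic carbon para to a large group gives a 1.0-fold higher number from compound 3 to compound 4 (0.02 log units; within the scatter), so the dimethylamino group is not needed to reach the level of compound 3. The plain phenyl amide also separates from both dimethylphenyl amides, with a 2.0-fold lower number from compound 2 to compound 4 (0.31 log units; beyond the scatter) and a 2.6-fold lower number from compound 1 to compound 4 (0.41 log units; beyond the scatter). Nothing available explains these results.

As far as these compounds go, whether methoxy, a carboxylic acid or a longer chain at this position would depart from hydrogen remains open. So does the effect of a single methyl on the ring.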